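Adding a 4-phenylphenyl group to compound 2

This account rests on a few compounds, and the source may have more. Where it says the series, first, only, none or still open, it means among the compounds named here.

Of the compounds shown here, two of one series have been tested in a functional assay on PC-3 cells (Homo sapiens) for antiproliferative activity, read by MTT assay, with a stated time of 72 h; on this read-out lower numbers stand for stronger inhibition and higher numbers for weaker inhibition. Compound 1, `CN(Cc1ccc(Oc2ccccc2)cc1)Cc1cn(C)c2ccc(CNc3ccc(F)cc3)cc12`, gives 56000 nM in this assay. Compound 2, `CN1CCN(Cc2cn(C)c3ccc(C(=O)Nc4ccc(F)cc4)cc23)CC1`, gives 89200 nM in this assay, the higher of the two numbers, although the gap to compound 1 lies within the scatter of repeated measurements, so no order between them can be read from these two values.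

The next compound, compound 3, `Cn1cc(CN2CCN(Cc3ccc(-c4ccccc4)cc3)CC2)c2cc(C(=O)Nc3ccc(F)cc3)ccc21`, differs from compound 2 in one place: 4-phenylphenyl in place of hydrogen on a saturated chain carbon bound to an amine nitrogen in a ring. Among the compounds with values here, no pair of measured compounds in this set differs by such a change, so there is no measured step to lean on; what can be said is only that compound 1, which also carries a large aromatic group on the chain carbon attached to the ring amine nitrogen, sits at 56000 nM, and that compound 2 sits at 89200 nM.

Given this, compound 3 is expected to show a moderate drop in number, a 3.0-fold lower number from compound 2 to compound 3 (0.47 log units; beyond the scatter), a step of a size that could reach beyond the scatter but need not. The estimate for compound 3 in this assay is 30000 nM, within a range from 8000 nM to 90000 nM.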

Compound 3, half-maximal inhibitory concentration: 37500 nM
For compound 3 the middle estimate is 1.3-fold (0.10 log units) below the measured one; the measured number falls inside the stated range.
By their numbers in this assay, from the lowest: compounds 3, 1 and 2 (each within the scatter of the next, the first and the last beyond it).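

In this assay, within the data shown here, the first measured change at this place is a 2.4-fold lower number from compound 2 to compound 3 (0.38 log units; beyond the scatter), a modest step that nonetheless lies beyond the scatter. Among these compounds, it shows that a saturated chain carbon bound to an amine nitrogen in a ring can carry 4-phenylphenyl, with its 12 heavy atoms and two six-membered aromatic rings of carbon only, without the number going up; the earlier compounds offered no such one-place comparison. Nothing at hand explains why the number falls, so the change stands only as an observed step in this single cell read-out.

The compounds shown leave open how much of the step needs the whole 4-phenylphenyl group, since a single phenyl ring or a methyl group at this place would separate the effect of the outer ring from that of the inner one. They also leave open whether an amine or a carboxylic acid on the outer ring would move the number further, or whether a longer chain between the ring amine nitrogen and the 4-phenylphenyl group would change the size of this step.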